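The source may report more compounds than this note shows. Statements on the series, on what has been measured and on what is new or still open speak of the compounds shown alone.

Measured in a functional assay on U-937 cells (Homo sapiens) for cytotoxicity, read by MTT assay, with a stated time of 24 h; on this read-out higher numbers stand for weaker inhibition and lower numbers for stronger inhibition:
Compound 1 `Nc1nn(Cc2cn(-c3ccc(F)c(Cl)c3)nn2)c2nc(-c3ccccc3)cc(C(F)(F)F)c12`: 99.1 ug/mL
Compound 2 `Nc1nn(Cc2cn(-c3ccc([N+](=O)[O-])cc3)nn2)c2nc(-c3ccccc3)cc(C(F)(F)F)c12`: 98.8 ug/mL

Compound 1 holds the higher of the two numbers, but only nominally, since compound 2 lies within the scatter of it. Compound 3 `Nc1nn(Cc2cn(-c3ccc(O)c([N+](=O)[O-])c3)nn2)c2nc(-c3ccccc3)cc(C(F)(F)F)c12` is unmeasured and departs from compound 1 at the aryl group on the aromatic nitrogen: 4-hydroxy-3-nitrophenyl in place of 3-chloro-4-fluorophenyl on an aromatic nitrogen. One measured step changes that same group, and it is a 1.0-fold lower number from compound 1 to compound 2 (0.00 log units; within the scatter). That single step gives no ground for expecting more than a shift within the scatter in this assay, with no firm direction. The expected change is a 1.2-fold lower number from compound 1 to compound 3 (0.07 log units; within the scatter). For compound 3 the estimate is 85 ug/mL, with an expected range of 40 ug/mL to 125 ug/mL.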

Compound 3, half-maximal inhibitory concentration: 41.3 ug/mL
Estimate against measurement, compound 3: 2.1-fold (0.31 log units) above; the range from low to high includes it.
By their numbers in this assay, from the lowest: compound 3; then compounds 2 and 1 (each within the scatter of the next).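

In this assay, the aryl group on the aromatic nitrogen proves able to shift the number beyond the scatter: 4-hydroxy-3-nitrophenyl gives a 2.4-fold lower number from compound 1 to compound 3 (0.38 log units; beyond the scatter) and a 2.4-fold lower number from compound 2 to compound 3 (0.38 log units; beyond the scatter). Compound 2 also carries a nitro group yet stays within the scatter of compound 1, so a nitro group on this ring does not suffice by itself. No measurement shown accounts for the step. Still open, from the compounds shown here alone, is whether 4-hydroxyphenyl alone would give the same step, and whether an amine or a carboxylic acid in place of the hydroxyl would keep it.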